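A few compounds are considered here, and "the series" means these few. Any claim that something is new, unique, unknown or untested is made for them only; others in the source may bear on it.

In a functional assay on DU-145 cells (Homo sapiens) for inhibition, read by trypan blue exclusion, with a stated time of 96 h (a higher number here means a weaker inhibitor of growth, a lower number a stronger inhibitor of growth), compound 3 (`COc1cc(/C=C(/SCc2ccc(Br)cc2)C(=O)c2ccc(C(=O)O)cc2)ccc1F`) gives 1000 nM, level with compound 1 (`O=C(/C(=C\c1ccc([N+](=O)[O-])c(O)c1)SCc1ccc(Br)cc1)c1ccc(C(F)(F)F)cc1`) at 1000 nM, the two sharing the lowest number of the three. Compound 2 (`O=C(O)c1ccc(C(=O)/C(=C\c2ccc(O)c([N+](=O)[O-])c2)SCc2ccc(Br)cc2)cc1`) gives 50000 nM. Compound 4 (`O=C(O)c1ccc(C(=O)/C(=C\c2ccc([N+](=O)[O-])c(O)c2)SCc2ccc(Br)cc2)cc1`) differs from compound 3 in one place: 3-hydroxy-4-nitrophenyl in place of 4-fluoro-3-methoxyphenyl on a double-bonded chain carbon bound to a double-bonded chain carbon. For the measured compounds named here, the only measured step at this place is large: a 50-fold lower number from compound 2 to compound 3 (1.70 log units; beyond the scatter). Compound 1 already carries the 3-hydroxy-4-nitrophenyl at 1000 nM, but it differs elsewhere, so only part of that large step is expected to reverse here. A rise beyond the scatter is therefore expected, as an 8.0-fold higher number from compound 3 to compound 4 (0.90 log units; beyond the scatter). For compound 4 the estimated value is 8000 nM, within an expected range of 1500 nM to 40000 nM.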

Compound 4, concentration for 50% growth inhibition: 10000 nM
Compound 4: middle estimate off by 1.3-fold (0.10 log units), on the low side, within the range that was stated.
By their numbers in this assay, from the lowest: compounds 1 and 3 (each within the scatter of the next); then compound 4; then compound 2.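

On the shared core with carboxy, the group on the double-bonded chain carbon sets the number in graded steps: a 10-fold higher number from compound 3 to compound 4 (1.00 log units; beyond the scatter), while a 5.0-fold lower number from compound 2 to compound 4 (0.70 log units; beyond the scatter), so the two hydroxy-nitrophenyl arrangements are not interchangeable. With 3-hydroxy-4-nitrophenyl held constant, the group on the aromatic carbon matters too: a 10-fold higher number from compound 1 to compound 4 (1.00 log units; beyond the scatter), with carboxy in place of trifluoromethyl. Nothing measured here explains these steps.

The compounds shown leave open how an aminophenyl group would fare on the double-bonded chain carbon. They also leave open whether a primary amide in place of carboxy would give a lower number.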